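Acetyl for methoxy on the anilino ring of compound 2

This account rests on a few compounds, and the source may have more. Where it says the series, first, only, none or still open, it means among the compounds named here.

Compound 1 `O=C1CCC(N2C(=O)c3ccc(Nc4ccccc4)cc3C2=O)C(=O)N1` and compound 2 `COc1ccc(Nc2ccc3c(c2)C(=O)N(C2CCC(=O)NC2=O)C3=O)cc1` share a core and differ only at the anilino ring. In an assay on FRT-Jurkat cells for inhibition of nuclear factor NF-kappa-B complex (Homo sapiens), read by flow cytometry, with a stated time of 24 h, tested at 10 uM (on this read-out lower numbers stand for less inhibition and higher numbers for more inhibition at the one concentration tested (going by the name of the read-out)), compound 1 gives 6%, while compound 2 gives 29%. The step of a number 23 percentage points higher from compound 1 to compound 2 (beyond the scatter) is the only measured one, and on these two numbers compound 2 stands highest.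

Compound 3 `CC(=O)c1ccc(Nc2ccc3c(c2)C(=O)N(C2CCC(=O)NC2=O)C3=O)cc1` carries the change (acetyl in place of methoxy on an aromatic carbon). Within the data shown here, no measured step covers acetyl against methoxy, so the size of this step is not known from the data. Among the measured compounds shown here, the one step in hand, from hydrogen to methoxy, was modest, and the move from one small group to another on the same aromatic carbon is expected to bring a step of no more than that size in either direction in this assay. Compound 3 is therefore estimated at 25%, with a range from 5% to 50%, which means an expected step of a number 4 percentage points lower from compound 2 to compound 3 (within the scatter).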

Compound 3, a percentage reported as inhibition, at one concentration (the size of the read-out at that concentration, not a potency): -2%
Compound 3: the middle estimate sits 27 percentage points above what was measured, outside the stated range (below it).
By their numbers in this assay, from the lowest: compounds 3 and 1 (each within the scatter of the next); then compound 2.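

Replacing methoxy with acetyl on this aromatic carbon, para to a large group, gives a number 31 percentage points lower from compound 2 to compound 3 (beyond the scatter) in this assay and so removes the gain seen with methoxy. Acetyl in place of hydrogen gives a number 8 percentage points lower from compound 1 to compound 3 (within the scatter) and thus leaves the two compounds level on this read-out, so a substituent at this place does not in itself raise the number: among the groups shown, only methoxy does. Nothing available bears on why methoxy and acetyl part so widely here.

The three compounds leave open whether the gain is particular to methoxy or also appears with a hydroxyl group, an amine, or a longer ether such as ethoxy. On these data alone, it is equally open whether a carboxylic acid or an amide at this place would behave like acetyl.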